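Moving the hydroxyl around the phenyl ring: what to expect

The compounds below may be only part of what the source reports. "The series", "measured", "known", "first", "only" and "open" are said of these compounds alone.

Measured so far:
compound 1 `COc1cc(N2C(N)=C(C#N)C(c3ccccc3O)C3=C2CC(C)(C)CC3=O)cc(OC)c1OC` with 2%
compound 2 `COc1cc(N2C(N)=C(C#N)C(c3ccc(Cl)cc3Cl)C3=C2CC(C)(C)CC3=O)cc(OC)c1OC` with 95%

Both compounds were tested in a functional assay on Ehrlich cells (Mus musculus) for cytotoxicity, tested at 50 ug/mL; a lower number here means a weaker effect, a higher number a stronger effect of the compound at the concentration tested. Compound 1 gives 2% and stands lowest of the two numbers; its nearest neighbour is compound 2, and the step of a number 93 percentage points higher from compound 1 to compound 2 (beyond the scatter) lies well beyond the scatter.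

Compound 3 `COc1cc(N2C(N)=C(C#N)C(c3ccc(O)cc3)C3=C2CC(C)(C)CC3=O)cc(OC)c1OC` has not been measured yet. It differs from compound 1 in one place: 4-hydroxyphenyl in place of 2-hydroxyphenyl on a saturated ring carbon. The group that leaves and the group that enters are the same size, each a six-membered aromatic ring with a single hydroxyl; only where the hydroxyl sits on that ring changes.

Among the compounds with values here, the only measured step, a number 93 percentage points higher from compound 1 to compound 2 (beyond the scatter), swaps the hydroxyphenyl for a dichlorophenyl and so bears only loosely on this change: it shows that the group on this saturated ring carbon can move the number a great deal, but nothing shows what a hydroxyl alone does in a new position. Compound 3 is therefore expected to stay near compound 1, with wide uncertainty, an expected step of a number 18 percentage points higher from compound 1 to compound 3 (beyond the scatter). The expected value for compound 3 in this assay is 20%, in the range 2% to 65%.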

Compound 3, a percentage reported as activity, at one concentration (the size of the read-out at that concentration, not a potency): 90%
Compound 3: the middle estimate sits 70 percentage points below what was measured; the measured number lies above the stated range.
By their numbers in this assay, from the lowest: compound 1; then compounds 3 and 2 (each within the scatter of the next).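

In this assay, compound 1 and compound 3 hold the same atoms, and 4-hydroxyphenyl in place of 2-hydroxyphenyl gives a number 88 percentage points higher from compound 1 to compound 3 (beyond the scatter). At this saturated ring carbon, then, where the hydroxyl sits on the phenyl ring can by itself separate a nearly empty read-out from a very high one, which the earlier comparison could not show because it changed the ring's substituents as well as their positions. A high number also does not depend on chlorine atoms in this pair, since 4-hydroxyphenyl in place of 2,4-dichlorophenyl gives a number 5 percentage points lower from compound 2 to compound 3 (within the scatter), and nothing available here explains the large effect of moving the hydroxyl.

The compounds shown leave open whether the 4-hydroxyl matters as a hydroxyl at all, or whether a methoxy group, an amine or a single chlorine atom in its place on the phenyl ring would give a similar number. Since each compound has a read-out at only one concentration, they also leave open how compound 2 and compound 3 would compare at lower concentrations, where a difference between them might appear.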